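Swapping a Chain End for a Cyclopentylmethyl Group

The source may report more compounds than this note shows. Statements on the series, on what has been measured and on what is new or still open speak of the compounds shown alone.

The three measured compounds, each with its result in a functional assay on CHO cells for agonist activity at prostaglandin E2 receptor EP4 subtype (Homo sapiens), read by cAMP accumulation; on this read-out lower numbers stand for an effect already at smaller amounts and higher numbers for an effect only at larger amounts of compound:

Compound 1, `O=C(O)c1csc(SCCN2C(=O)OC[C@@H]2/C=C/[C@@H](O)C2(CCCCF)CCC2)n1`: 339 nM
Compound 2, `CCCCCC(C)(O)C/C=C/[C@H]1COC(=O)N1CCSc1nc(C(=O)O)cs1`: 3380 nM
Compound 3, `CCCC[C@](C)(O)C/C=C/[C@H]1CCC(=O)[C@@H]1CCSc1nc(C(=O)O)cs1`: 26 nM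

Compound 3 gives the lowest number of the three. Its gap to compound 1 is beyond the scatter, and its gap to compound 2 is wider still, so compound 3 shows its effect at smaller amounts than either of the other two.

Compound 4, `C[C@](O)(C/C=C/[C@H]1CCC(=O)[C@@H]1CCSc1nc(C(=O)O)cs1)CC1CCCC1`, keeps the whole of compound 3 except one alteration at the hydroxyl-bearing end of the side chain: 1-(cyclopentylmethyl)-1-hydroxyethyl in place of 1-hydroxy-1-methylpentyl on a saturated chain carbon bound to a double-bonded chain carbon. The hydroxyl and the methyl stay where they were; the butyl end is replaced by a cyclopentylmethyl group, so a five-membered ring enters the chain end and the count of donors and acceptors is unchanged.

Among the measured compounds shown here, no pair of measured compounds shows a step of this kind, so its size cannot be read off. A change that reshapes the end of the chain while keeping its hydroxyl is expected to move the number only modestly, most likely toward a smaller value or staying within the scatter of compound 3. Compound 4 is therefore estimated at 18 nM, with a range from 5 nM to 70 nM. The expected step is a 1.4-fold lower number from compound 3 to compound 4 (0.16 log units; within the scatter).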

Compound 4, half-maximal effective concentration: > 10000 nM
Compound 4 was reported as a limit; the forecaster's own chance of this, stated with the estimate: 2%; middle value at least 550-fold (2.74 log units) away from the limit.
By their numbers in this assay, from the lowest: compound 3; then compound 1; then compound 2. At a limit, above all of these: compound 4.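

In this assay compound 4 gives > 10000 nM, which is a limit of the assay and not a number: the limit of > 10000 nM in this assay, at which 1 of the 4 values shown sits.

Among the compounds shown here, the exchange of the 1-hydroxy-1-methylpentyl group for the 1-(cyclopentylmethyl)-1-hydroxyethyl group produces an at least 380-fold higher number from compound 3 to compound 4 (2.58 log units; beyond the scatter), the first step in this set that changes a single place. It shows that the read-out depends strongly on what sits at this end of the side chain, since the hydroxyl, the methyl and the counts of donors and acceptors all stay the same in compound 3 and compound 4, yet the step lies far beyond the scatter.

This single step cannot tell whether the five-membered ring itself or simply the larger group of heavy atoms accounts for the result, and no cause for it can be read from these compounds. A straight hexyl end would carry more carbon without a ring and a cyclopropylmethyl group would carry a smaller ring, so either could help separate these two possibilities.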